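Removing both chlorines in the oxane-cored analogue

A few compounds are considered here, and "the series" means these few. Any claim that something is new, unique, unknown or untested is made for them only; others in the source may bear on it.

Three compounds of the series have numbers in a functional assay on HL-60 cells (Homo sapiens) for antiproliferative activity, read by MTT assay, with a stated time of 72 h; a lower number here means a stronger inhibitor, a higher number a weaker inhibitor. Compound 1 `NC1=NC2(CCSCC2)N(OCCCOc2cccc(Cl)c2)C(N)=N1` gives 260 nM, compound 3 `NC1=NC2(CCSCC2)N(OCCCOc2cccc(Cl)c2Cl)C(N)=N1` gives 30 nM, and compound 2 `NC1=NC2(CCOCC2)N(OCCCOc2ccc(Cl)c(Cl)c2)C(N)=N1` gives 1240 nM, the highest of the three values, with compound 3 the lowest. The one single-point step shown, an 8.7-fold lower number from compound 1 to compound 3 (0.94 log units; beyond the scatter), adds a chloro to the ring on the chain and lowers the number.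

Compound 4 `Cc1ccc(OCCCON2C(N)=NC(N)=NC23CCOCC3)cc1` differs from compound 2 in that (4-methylphenyl in place of 3,4-dichlorophenyl on an oxygen on a saturated carbon). This change runs the other way from the step between compound 1 and compound 3: both chlorines leave the aromatic ring and only a methyl enters. Among the compounds with values here, on that basis the number for compound 4 is expected to rise rather than fall, by a step of the order of a 2.4-fold higher number from compound 2 to compound 4 (0.38 log units; beyond the scatter), though the methyl has no precedent here and the core of compound 2 is not the core of compound 1 or compound 3, so the expectation is loosely held. For compound 4 the expected value is 3000 nM, within a range of 1000 nM to 9000 nM.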

Compound 4, half-maximal inhibitory concentration: 2580 nM
For compound 4 the middle estimate is 1.2-fold (0.07 log units) above the measured one, within the range that was stated.
By their numbers in this assay, from the lowest: compound 3; then compound 1; then compound 2; then compound 4.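

In this assay, within the data shown here, the exchange of 3,4-dichlorophenyl for 4-methylphenyl on an oxygen on a saturated carbon gives a 2.1-fold higher number from compound 2 to compound 4 (0.32 log units; beyond the scatter), the first single-place step on the core of compound 2. Its direction matches that of an 8.7-fold lower number from compound 1 to compound 3 (0.94 log units; beyond the scatter), so in both listed pairs the compound with more chlorine on the aromatic ring has the lower number, although the two steps involve different cores and different ring patterns. Nothing at hand explains either step.

This single exchange removes both chlorines and adds a methyl, so their separate contributions cannot be told apart; phenyl with no substituent or 4-chlorophenyl at this place would address that. Also open, from the compounds shown here alone, is whether 4-methylphenyl on the core of compound 1 would shift the number in the same direction.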